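This account rests on a few compounds, and the source may have more. Where it says the series, first, only, none or still open, it means among the compounds named here.

Compound 1 `O=C(NNC(=O)C1CC1c1ccc(OC(F)(F)F)cc1)c1ccncc1`: > 100000 nM
Compound 2 `CCOc1ccc(C2CC2C(=O)NNC(=O)c2ccncc2)cc1`: > 100000 nM
Compound 3 `O=C(NNc1nncc2ccccc12)C1CC1c1ccc(OC(F)(F)F)cc1`: 92000 nM

Compound 1 sits at a limit of a functional assay on PC-3 cells (Homo sapiens) for inhibition, read by MTT assay, with a stated time of 72 h (a higher number here means a weaker inhibitor, a lower number a stronger inhibitor), not at a number. Compound 2 likewise sits at a limit of this assay. Among the measured compounds shown here, compound 3 gives the only number among the three, and it is a weak one. Compound 4 `CC(C)=CCC/C(C)=C/COc1ccc(C2CC2C(=O)NNc2nncc3ccccc23)cc1` differs from compound 3 by 3,7-dimethylocta-2,6-dien-1-yl in place of trifluoromethyl on an oxygen on an aromatic ring. For the measured compounds named here, the one measured step, a step that the two limits leave unreadable from compound 1 to compound 2, cannot be read because the limit of > 100000 nM in this assay, at which 2 of the 3 values shown sit, places both of its ends at a limit, so no measured step bears on the change to compound 4, and its size is open. The step is therefore expected to be a 2.3-fold lower number from compound 3 to compound 4 (0.36 log units; beyond the scatter). Compound 4 is estimated at 40000 nM, with a range from 8000 nM to 200000 nM.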

Compound 4, half-maximal inhibitory concentration: 24000 nM
For compound 4 the middle estimate is 1.7-fold (0.22 log units) above the measured one; the range from low to high includes it.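

In this assay, the place on an oxygen on an aromatic ring now gives its first readable change: 3,7-dimethylocta-2,6-dien-1-yl in place of trifluoromethyl brings a 3.8-fold lower number from compound 3 to compound 4 (0.58 log units; beyond the scatter), a modest step. The earlier change at this place cannot be read: the limit of > 100000 nM in this assay, at which 2 of the 4 values shown sit. Nothing measured here gives a cause for the new step.

Going by these compounds, it remains open whether the chain's length or its double bonds matter, which a saturated decyl chain on the same oxygen would separate. Also open, on these data alone, is how a shorter 3-methylbut-2-en-1-yl chain or a terminal amine would read there.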